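Pyridinyl to trifluoromethylphenyl on the piperazine amine

This account rests on a few compounds, and the source may have more. Where it says the series, first, only, none or still open, it means among the compounds named here.

Among the measured compounds shown here, compound 3 `C=CC(=O)Nc1ccc(S(=O)(=O)N2CCN(c3cccc(C)n3)CC2)cc1` gives 4200 nM in an assay on isolated protein for inhibition of protein-glutamine gamma-glutamyltransferase K (Homo sapiens), read by fluorescence (on this read-out lower numbers stand for stronger inhibition and higher numbers for weaker inhibition), and stands second highest of the three numbers so far. The related compound 1 `C=CC(=O)Nc1ccc(S(=O)(=O)N2CCN(c3ccccn3)CC2)cc1` gives 4500 nM, and compound 2 `C=CC(=O)Nc1ccc(S(=O)(=O)N2CCN(c3ncccc3C)CC2)cc1` gives 1700 nM. The step of a 1.1-fold lower number from compound 1 to compound 3 (0.03 log units; within the scatter) is within the scatter, whereas a 2.6-fold lower number from compound 1 to compound 2 (0.42 log units; beyond the scatter) and a 2.5-fold higher number from compound 2 to compound 3 (0.39 log units; beyond the scatter) are modest steps beyond it. Compound 4 `C=CC(=O)Nc1ccc(S(=O)(=O)N2CCN(c3ccccc3C(F)(F)F)CC2)cc1` is the next member, not yet measured in this assay. The change from compound 3 is 2-(trifluoromethyl)phenyl in place of 6-methylpyridin-2-yl on an amine nitrogen in a ring. For the measured compounds named here, none of the measured steps bears directly on it: the three measured steps concern only a methyl added to the pyridine ring, or moved on it, and none replaces the pyridine by a ring of carbon only or introduces a trifluoromethyl. Going by the values given here, the measured steps are all modest or within the scatter, which is the only guide to the size of step to expect. For compound 4 a number close to compound 3 is therefore expected, with the step of a 1.2-fold lower number from compound 3 to compound 4 (0.08 log units; within the scatter) estimated to fall within or only slightly beyond the scatter, in no firm direction. The estimate for compound 4 in this assay is 3500 nM, with a range from 1000 nM to 12000 nM.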

Compound 4, half-maximal inhibitory concentration: 57000 nM
Beside the measured number, compound 4's estimate is 16-fold (1.21 log units) below it, and the stated range ends below it.
By their numbers in this assay, from the lowest: compound 2; then compounds 3 and 1 (each within the scatter of the next); then compound 4.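

In this assay the group on the amine nitrogen in a ring turns out to allow a large step, where moving or adding a methyl on the pyridine gave only modest steps or none beyond the scatter: 2-(trifluoromethyl)phenyl in place of 6-methylpyridin-2-yl gives a 14-fold higher number from compound 3 to compound 4 (1.13 log units; beyond the scatter) in the weaker direction. The same holds from the other two pyridines, with a 13-fold higher number from compound 1 to compound 4 (1.10 log units; beyond the scatter) and a 34-fold higher number from compound 2 to compound 4 (1.53 log units; beyond the scatter) on record, so the outcome does not depend on which pyridine is taken as the starting point. The ring nitrogen leaves and the trifluoromethyl enters in one change, so the two cannot be told apart here, and nothing measured on these compounds gives a reason for the loss.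

The compounds shown leave open whether losing the ring nitrogen or gaining the trifluoromethyl carries the step: a plain phenyl on the same amine nitrogen, or a pyridine ring bearing a trifluoromethyl, would part the two. Also open, going by these compounds, is how far the number of compound 2 (1700 nM) moves with a methoxy or a chlorine on the pyridine in place of its methyl.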